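The compounds below may be only part of what the source reports. "The series", "measured", "known", "first", "only" and "open" are said of these compounds alone.

Compound 1, `C=C[C@@](C)(/C=C/c1ccc(OCc2cn(-c3ccccc3)nn2)cc1)CCC=C(C)C`, gives 172000 nM in a toxicity assay on RAW264.7 cells (Mus musculus) for cytotoxicity, read by MTT assay, with a stated time of 24 h; on this read-out lower numbers stand for stronger inhibition and higher numbers for weaker inhibition. Compound 2, `C=C[C@@](C)(/C=C/c1ccc(OCc2cn(-c3ccc(F)cc3)nn2)cc1)CCC=C(C)C`, gives 233000 nM in this assay. Compound 3, `C=C[C@@](C)(/C=C/c1ccc(OCC(=O)Nc2ccccc2)cc1)CCC=C(C)C`, gives 63300 nM in this assay.

Compound 2 carries fluoro in place of hydrogen on an aromatic carbon relative to compound 1, and this change made a 1.4-fold higher number from compound 1 to compound 2 (0.13 log units; within the scatter). Compound 3 has a different core from compound 1; the difference between the two cores is not broken down here, but compound 3 shows the lowest number of the three.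

Compound 4, `C=C[C@@](C)(/C=C/c1ccc(OCC(=O)Nc2ccc(F)cc2)cc1)CCC=C(C)C`, has not yet been measured. It differs from compound 3 by fluoro in place of hydrogen on an aromatic carbon, the same change that separates compound 2 from compound 1. The step from compound 3 to compound 4 in this assay is expected to be a 1.3-fold higher number from compound 3 to compound 4 (0.10 log units; within the scatter), because the same change gave a 1.4-fold higher number from compound 1 to compound 2 (0.13 log units; within the scatter). Compound 4 is therefore estimated at 80000 nM, with a range from 35000 nM to 180000 nM.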

Compound 4, half-maximal inhibitory concentration: 59100 nM
Estimate against measurement, compound 4: 1.4-fold (0.13 log units) above; the measured number falls inside the stated range.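

In this assay, the change from phenyl to 4-fluorophenyl gave a 1.1-fold lower number from compound 3 to compound 4 (0.03 log units; within the scatter). Set beside the earlier step, the same change shows no detectable dependence on the core: the same change on two cores in this assay, a 1.4-fold higher number (0.13 log units; within the scatter) from compound 1 to compound 2 and a 1.1-fold lower number (0.03 log units; within the scatter) from compound 3 to compound 4, 1.5-fold (0.16 log units) apart, within the scatter of two such steps This shows only that the change stayed within the scatter on both cores; resting on two pairs and a single small change, it does not show that the two cores would respond alike to a larger change, nor that fluoro would behave the same way on any other core in the series.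

The compounds shown leave open whether another group in that place, such as chloro, methoxy, an amine or a carboxylic acid, would give a step beyond the scatter on either core.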